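The source may hold more compounds than are shown below. What is called first, only, known or untested is meant among the compounds shown, and "the series" means these compounds.

Compound 1 `COc1cc(NCc2ccc(Cl)s2)ccc1-c1cnco1` gives 53800 nM in an ADME assay on Vero cells (Chlorocebus sabaeus) for cytotoxicity, read by MTT assay, with a stated time of 96 h; a lower number here means that less compound is tolerated, a higher number that more compound is tolerated.
Compound 2 `COc1cc(NCc2scnc2C)ccc1-c1cnco1` gives 73700 nM in this assay.
Compound 3 `COc1ccc(-c2cnco2)cc1NCc1cccs1` gives 53800 nM in this assay.

Compound 2 has the highest of the three numbers, but its nearest neighbour compound 1 and its furthest neighbour compound 3 both sit within the scatter of it, so the three measured compounds cannot be told apart by these values. The step of a 1.4-fold higher number from compound 1 to compound 2 (0.14 log units; within the scatter) illustrates this: swapping 4-methyl-1,3-thiazol-5-yl in for 5-chlorothiophen-2-yl on a saturated chain carbon bound to a nitrogen on an aromatic ring left the number essentially unchanged.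

Compound 4 `CCc1ccc(CNc2ccc(-c3cnco3)c(OC)c2)s1` has not yet been measured. The change from compound 2 is 5-ethylthiophen-2-yl in place of 4-methyl-1,3-thiazol-5-yl on a saturated chain carbon bound to a nitrogen on an aromatic ring. Within the data shown here, the only measured step that bears on it is the one from compound 1 to compound 2, which exchanged one such ring for another at the same place and stayed within the scatter. The step from compound 2 to compound 4 reverses that kind of exchange, putting a thiophene-type ring back in place of the thiazole-type ring, so no step beyond the scatter is expected in either direction; the expected step is a 1.3-fold lower number from compound 2 to compound 4 (0.10 log units; within the scatter).

For compound 4 the estimated value in this assay is 58000 nM, with a range from 30000 nM to 110000 nM.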

Compound 4, half-maximal cytotoxic concentration: 13600 nM
For compound 4 the middle estimate is 4.3-fold (0.63 log units) above the measured one; the measured number lies below the stated range.
By their numbers in this assay, from the lowest: compound 4; then compounds 1, 3 and 2 (each within the scatter of the next).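

On a saturated chain carbon bound to a nitrogen on an aromatic ring, putting 5-ethylthiophen-2-yl in place of 4-methyl-1,3-thiazol-5-yl gives, in this assay, a 5.4-fold lower number from compound 2 to compound 4 (0.73 log units; beyond the scatter), so the group at this place can shift how much compound the cells tolerate, which the earlier ring exchange did not show. Ethyl in place of chloro on an aromatic carbon gives a 4.0-fold lower number from compound 1 to compound 4 (0.60 log units; beyond the scatter), and since compound 1 also carries a thiophene ring yet stays within the scatter of compound 2, the thiophene ring alone does not go with the lower number; the drop appears only when the ethyl group is present. No measurement shown here explains this drop.

The compounds shown leave open whether the effect belongs to ethyl in particular or grows with chain length, which a methyl or a propyl group in place of the ethyl on the same thiophene ring could show. They also leave open how an amine or a carboxylic acid at the end of such a chain would read in this assay.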